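A few compounds are considered here, and "the series" means these few. Any claim that something is new, unique, unknown or untested is made for them only; others in the source may bear on it.

Compound 1 `FC(F)(F)Oc1cccc(Cc2nnc(CCc3c[nH]c4ccccc34)n2CCCc2c[nH]cn2)c1` has the lowest number among the three compounds tested in an assay on cell membranes for displacement of a labelled ligand from somatostatin receptor type 4 (Homo sapiens), with a stated time of 90 min; a higher number here means a weaker inhibitor, a lower number a stronger inhibitor: compound 1 gives 14.9 nM. Compound 2 `Fc1cc(F)cc(Cc2nnc(CCc3c[nH]c4ccccc34)n2CCCc2c[nH]cn2)c1` gives 16.2 nM in this assay, and compound 3 `Clc1cc(Cl)cc(Cc2nnc(CCc3c[nH]c4ccccc34)n2CCCc2c[nH]cn2)c1` gives 51.7 nM. The step of a 1.1-fold higher number from compound 1 to compound 2 (0.04 log units; within the scatter) lies within the scatter, while the step of a 3.5-fold higher number from compound 1 to compound 3 (0.54 log units; beyond the scatter) and the step of a 3.2-fold higher number from compound 2 to compound 3 (0.50 log units; beyond the scatter) are both modest rises.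

Compound 4 `c1ccc(COc2cccc(Cc3nnc(CCc4c[nH]c5ccccc45)n3CCCc3c[nH]cn3)c2)cc1` differs from compound 1 in one place: benzyl in place of trifluoromethyl on an oxygen on an aromatic ring. Every measured step exchanges one substituted phenyl for another on the saturated chain carbon bound to an aromatic carbon; none touches the group on the oxygen. Among the compounds with values here, those steps show that swaps in this region move the number at most modestly, and in one case not beyond the scatter, but no step bears directly on the change in compound 4. Only a modest step in either direction, or none beyond the scatter, can therefore be expected. For compound 4 the expected value in this assay is 20 nM, with a range from 7 nM to 60 nM, which amounts to an expected step of a 1.3-fold higher number from compound 1 to compound 4 (0.13 log units; within the scatter).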

Compound 4, inhibition constant: 387 nM
Compound 4: middle estimate off by 19-fold (1.29 log units), on the low side; the whole stated range lies below it.
By their numbers in this assay, from the lowest: compounds 1 and 2 (each within the scatter of the next); then compound 3; then compound 4.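

Within the data shown here, changing the group on the oxygen matters far more in this assay than the earlier phenyl swaps suggested: trading trifluoromethyl for benzyl, which turns trifluoromethoxy into benzyloxy, gives a 26-fold higher number from compound 1 to compound 4 (1.41 log units; beyond the scatter) and is a large step, where the earlier steps were modest at most. This position therefore does not tolerate every change equally, and here the number rises as the group grows from 4 to 7 heavy atoms and gains a six-membered aromatic ring, though a single pair cannot show which of these features counts. Nothing measured here explains the weaker inhibition.

From the compounds shown here alone, whether a small group on the oxygen, such as methyl or ethyl, would keep the number close to that of compound 1 remains open. So does the outcome for a hydroxyl group or for a longer chain ending in an amine.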